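The source may hold more compounds than are shown below. What is called first, only, known or untested is meant among the compounds shown, and "the series" means these compounds.

Measured compounds:
- compound 1, `O=S(=O)(c1ccc(F)cc1)c1cnc2c(F)cccc2c1-c1cccc(F)c1`: 1.56 mL/min
- compound 2, `O=S(=O)(c1ccc(F)c(F)c1)c1cnc2c(F)cccc2c1-c1cccc(F)c1`: 1.28 mL/min

In an ADME assay on microsomes from liver (Homo sapiens) for metabolic stability, tested at 2.5 uM (a lower number here means slower removal, a higher number faster removal of the compound), compound 1 gives 1.56 mL/min and compound 2 gives 1.28 mL/min. Compound 1 holds the higher of the two numbers, but its gap to compound 2 is only a 1.2-fold lower number from compound 1 to compound 2 (0.09 log units; within the scatter), so the two compounds cannot be told apart in this assay. Within the data shown here, that single measured step, fluoro in place of hydrogen on an aromatic carbon, is the only step-to-step comparison at hand.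

Compound 3, `COc1ccc(-c2c(S(=O)(=O)c3ccc(F)cc3)cnc3c(F)cccc23)cc1`, has not yet been measured in this assay. It differs from compound 1 in 4-methoxyphenyl in place of 3-fluorophenyl on an aromatic carbon. Among the measured compounds shown here, no measured step touches this part of the shared core: the step from compound 1 to compound 2 alters a different ring and stays within the scatter, so it gives no guide to the size or direction of the present change.

With nothing measured to lean on, compound 3 is expected to sit close to compound 1, with a step of a 1.3-fold higher number from compound 1 to compound 3 (0.11 log units; within the scatter) that may itself fall within the scatter. The estimated value for compound 3 in this assay is 2 mL/min, within a range from 0.9 mL/min to 4.5 mL/min.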

Compound 3, intrinsic clearance in a liver preparation (reported as CLH), per the amount of preparation that the assay uses: 2.41 mL/min
Compound 3: the middle estimate sits 1.2-fold (0.08 log units) below what was measured; the range from low to high includes it.
By their numbers in this assay, from the lowest: compounds 2, 1 and 3 (each within the scatter of the next).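

Among these compounds, the first measured change at this position, 4-methoxyphenyl in place of 3-fluorophenyl on the aromatic carbon opposite the ring nitrogen, gives a 1.5-fold higher number from compound 1 to compound 3 (0.19 log units; within the scatter) in this assay, so compound 1 and compound 3 cannot be told apart there. Among the compounds shown here, the one earlier step altered a different ring, so this result adds something new: on the shared core, this position accepted one exchange of an aromatic ring for another, with a different substituent at a different place on that ring, without a step beyond the scatter. No measurement at hand explains this result, and its small size should not be read as a general property of the position.

This single step changes both the substituent and its place on the ring, so the compounds shown do not separate the loss of fluoro from the gain of methoxy, or the 3-position from the 4-position. They also leave open whether an amine or a carboxylic acid on this ring, a longer chain in place of methoxy, or a morpholine in place of the whole ring would move the number beyond the scatter.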